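A methyl group added to the core of compound 1

The compounds below may be only part of what the source reports. "The series", "measured", "known", "first", "only" and "open" are said of these compounds alone.

Going by the values given here, in an ADME assay on MT4 cells (Homo sapiens) for cytotoxicity, read by MTT assay, with a stated time of 5 days (a lower number here means that less compound is tolerated, a higher number that more compound is tolerated), compound 1 `N#Cc1ccc(Nc2nccc(OCC(=O)Nc3ccc(Cl)cc3)n2)cc1` gives 162000 nM as the only exact number so far. Compound 2 `N#Cc1ccc(Nc2nccc(OCC(=O)Nc3ccc(C#N)cc3F)n2)cc1` reads > 321000 nM and that is a limit of the assay, not a number. Compound 3 `COc1ccc(NC(=O)COc2ccnc(Nc3ccc(C#N)cc3)n2)cc1` reads > 333000 nM and that too is a limit.

Compound 4 `Cc1cnc(Nc2ccc(C#N)cc2)nc1OCC(=O)Nc1ccc(Cl)cc1` carries one change against compound 1: methyl in place of hydrogen on an aromatic carbon with methyl in place of hydrogen on an aromatic carbon of the six-membered aromatic ring with 2 nitrogen, para to the (4-cyanophenyl)amino group.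

Two measured steps start from compound 1, and both alter the aromatic group on the amide-type nitrogen rather than that carbon. They are an at least 1.9-fold higher number from compound 1 to compound 2 (0.29 log units; that floor lies within the scatter) and an at least 2.0-fold higher number from compound 1 to compound 3 (0.31 log units; beyond the scatter) as far as the limits let them be read. Both are only floors, neither involves a methyl group, and so they give this change no direction. With compound 1 at 162000 nM as the starting point, no step beyond the scatter is expected in this assay for compound 4. The expected size is a 1.1-fold lower number from compound 1 to compound 4 (0.03 log units; within the scatter) in this estimate. Compound 4 is estimated at 150000 nM within a range from 70000 nM to 320000 nM for repeated measurements.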

Compound 4, half-maximal cytotoxic concentration: > 317000 nM
Compound 4 was reported as a limit (the forecaster's own chance of this, stated with the estimate: 15%); at least 2.1-fold (0.32 log units) between middle value and limit.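

In this assay compound 4 is reported as a limit and not as a number: the limit of > 317000 nM in this assay, at which 1 of the 4 values shown sits. Methyl in place of hydrogen on this aromatic carbon, ortho to a large group and two atoms from the ring nitrogen, is the only change shown on the shared core rather than on the aromatic group on the amide-type nitrogen, and it gives an at least 1.9-fold higher number from compound 1 to compound 4 (0.29 log units; that floor lies within the scatter). Going by these compounds alone, the earlier compounds said nothing about this carbon; now it is clear that adding a methyl group here does not bring a drop in the tolerated concentration, although the floor alone does not establish a true rise and the real size of the step stays unknown.

Methyl is the only group shown at this carbon, so whether an ethyl group or an amine in the same place would give the same picture remains open. Also open, on these data alone, is how the methyl group would read with the 4-methoxyphenyl group of compound 3 on the amide-type nitrogen, and how far above the limit the true value of compound 4 lies.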